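Nitro-to-hydrogen step in a cytotoxicity series

This account rests on a few compounds, and the source may have more. Where it says the series, first, only, none or still open, it means among the compounds named here.

Measured so far:
compound 1, `COc1cc(N(C)C(=O)c2cccc([N+](=O)[O-])c2)cc(OC)c1OC`: >= 125000 nM
compound 2, `COc1cc(N(C)C(=O)N(C)c2cccc([N+](=O)[O-])c2)cc(OC)c1OC`: >= 125000 nM
compound 3, `COc1cc(NC(=O)c2cccc([N+](=O)[O-])c2)cc(OC)c1OC`: >= 125000 nM

In a functional assay on Daoy cells (Homo sapiens) for cytotoxicity, read by MTT assay, with a stated time of 72 h (a higher number here means a weaker inhibitor, a lower number a stronger inhibitor), compound 1 gives >= 125000 nM, which is a limit of the assay and not a number. Compound 2 likewise sits only at a limit, >= 125000 nM. Compound 3 also gives only a limit, >= 125000 nM. Within the data shown here, the one single-point step, a step that the two limits leave unreadable from compound 1 to compound 3, therefore cannot be read in size or direction. Compound 4, `COc1cc(N(C)C(=O)c2ccccc2)cc(OC)c1OC`, differs from compound 1 by hydrogen in place of nitro on an aromatic carbon. Among the measured compounds shown here, no measured step bears on this change; the only reading available is the limit of >= 125000 nM in this assay, at which 3 of the 3 values shown sit. With no number to move from, compound 4 is expected to remain at the limit as well. The expected step is a number no higher from compound 1 to compound 4 (the limit leaves the size open), none readable beyond the scatter. Compound 4 is estimated at 125000 nM, with a range from 60000 nM to 300000 nM.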

Compound 4, half-maximal inhibitory concentration: >= 125000 nM
Compound 4: a limit, no number; the forecaster's own chance of this, stated with the estimate: 85%; the middle value lies on the limit itself.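

Compound 1 and compound 4 both sit only at a limit of the assay, so no step can be read between them. The compounds shown leave open whether hydrogen in place of nitro changes cytotoxicity at all, with no number yet to compare: the limit of >= 125000 nM in this assay, at which 4 of the 4 values shown sit.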